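This account rests on a few compounds, and the source may have more. Where it says the series, first, only, none or still open, it means among the compounds named here.

Compound 1, `N#Cc1cnc(NCc2cnccc2C(F)(F)F)cc1N[C@H]1C[C@@H](O)C1`, gives 500 nM in an assay on isolated protein for inhibition of protein kinase C theta type (Homo sapiens), read by TR-FRET, with a stated time of 2 h; on this read-out higher numbers stand for weaker inhibition and lower numbers for stronger inhibition.
Compound 2, `N#Cc1cnc(NCc2cnccc2C(F)(F)F)cc1NC[C@H]1C[C@H](O)C1`, gives 700 nM in this assay.
Compound 3, `N#Cc1cnc(NCc2cnccc2C(F)(F)F)cc1NC1CCOCC1`, gives 900 nM in this assay.

Compound 3 carries the largest of the three numbers as written, but this says little: the step of a 1.8-fold higher number from compound 1 to compound 3 (0.26 log units; within the scatter) and the step of a 1.3-fold higher number from compound 2 to compound 3 (0.11 log units; within the scatter) are both within the scatter, so nothing separates compound 3 from the other two on the evidence at hand.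

The next compound, compound 4, `N#Cc1cnc(NCc2cnccc2C(F)(F)F)cc1NCC1CCOCC1`, differs from compound 3 in one place: (oxan-4-yl)methyl in place of oxan-4-yl on a nitrogen on an aromatic ring. For the measured compounds named here, one measured step bears directly on this kind of change. Between compound 1 and compound 2 the same kind of alteration was made, a cyclic substituent on the nitrogen on the aromatic ring being replaced by the same ring attached through a methylene group, and the result was a 1.4-fold higher number from compound 1 to compound 2 (0.15 log units; within the scatter), a step within the scatter. On that basis the author expects the change from compound 3 to compound 4 to be of similar size, a 1.2-fold higher number from compound 3 to compound 4 (0.09 log units; within the scatter), with no movement beyond the scatter, if anything a slightly higher number. The estimate for compound 4 in this assay is therefore 1100 nM, within a range from 500 nM to 2500 nM.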

Compound 4, half-maximal inhibitory concentration: 400 nM
The estimate for compound 4 lay 2.8-fold (0.44 log units) above the measured number; measured number below the stated range.
By their numbers in this assay, from the lowest: compounds 4, 1, 2 and 3 (each within the scatter of the next, the first and the last beyond it).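

For the compounds shown here, replacing oxan-4-yl with (oxan-4-yl)methyl on a nitrogen on an aromatic ring gives a 2.3-fold lower number from compound 3 to compound 4 (0.35 log units; beyond the scatter) in this assay, so this is the first step that lies beyond the scatter, though it is modest. The corresponding change on the 3-hydroxycyclobutyl group gives a 1.4-fold higher number from compound 1 to compound 2 (0.15 log units; within the scatter) and stays within the scatter, so the outcome of adding the methylene group at this position is not shown to carry over from one ring to the other. Compound 4 does not stand apart from the two compounds with a hydroxyl group, since both a 1.8-fold lower number from compound 2 to compound 4 (0.24 log units; within the scatter) and a 1.3-fold lower number from compound 1 to compound 4 (0.10 log units; within the scatter) are within the scatter, and the effect of this change is therefore visible only against compound 3.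

Nothing at hand accounts for the step from oxan-4-yl to (oxan-4-yl)methyl. The compounds shown leave open whether the lower number would hold with a longer chain, as in (oxan-4-yl)ethyl, or with an amine in the ring, as in (piperidin-4-yl)methyl, on the same nitrogen.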